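Moving the Methyl on the Aryl Ring of Compound 1

The compounds below may be only part of what the source reports. "The series", "measured", "known", "first", "only" and "open" are said of these compounds alone.

Among the measured compounds shown here, compound 1 `Cc1cccc(/N=C2/NC(=O)/C(=C/c3ccccn3)S2)c1` is one of three compounds measured in a functional assay on the whole organism (strain Swiss albino) for inhibition, with Mus musculus as the target, in the writhing test, with stated times of 30 min and 15 min, at a dose of 50 mg/kg by the oral route; a higher number here means more inhibition at the dose given (going by the name of the read-out), a lower number less inhibition. In this assay compound 1 gives 52.3%, the second highest of the three numbers. For the measured compounds named here, its nearest neighbour is compound 2 `O=C1N/C(=N/c2cccc([N+](=O)[O-])c2)S/C1=C\c1ccccn1`, which in this assay gives 62.3%; the single step of a number 10 percentage points higher from compound 1 to compound 2 (within the scatter) lies within the scatter. Furthest away is compound 3 `O=C1N/C(=N/c2ccc([N+](=O)[O-])cc2Cl)S/C1=C\c1ccccn1`, which in this assay gives 37.4%; set against compound 1 the two values differ beyond the scatter, but no single-change step links these two compounds.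

Compound 4 `Cc1ccccc1/N=C1/NC(=O)/C(=C/c2ccccn2)S1` has not yet been measured in this assay. It differs from compound 1 by 2-methylphenyl in place of 3-methylphenyl on a double-bonded nitrogen. Both compounds hold the same atoms; only the way the methyl is joined to the aryl ring changes. Going by the values given here, no measured step bears on a change of this kind: the one measured single-change step exchanges one group for another and stays within the scatter, and no measured step keeps the same atoms and joins them differently. On that basis compound 4 is expected to show no step beyond the scatter, a number 2.3 percentage points lower from compound 1 to compound 4 (within the scatter). The estimate for compound 4 in this assay is 50%, with a range from 36% to 64%.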

Compound 4, a percentage reported as inhibition, in the whole organism at one dose (the size of the read-out at that dose, not a potency): 43.6%
Compound 4: the middle estimate sits 6.4 percentage points above what was measured; the range from low to high includes it.
By their numbers in this assay, from the lowest: compounds 3, 4, 1 and 2 (each within the scatter of the next, the first and the last beyond it).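

With the same atoms joined differently, 2-methylphenyl in place of 3-methylphenyl on a double-bonded nitrogen gives, in this assay, a number 8.7 percentage points lower from compound 1 to compound 4 (within the scatter). This is the only step shown that keeps the atoms and changes only how the methyl is joined to the aryl ring, and it adds a second kind of change at this aryl group to the exchange of methyl for nitro, a number 10 percentage points higher from compound 1 to compound 2 (within the scatter); neither single step leaves the scatter, so the two methyl isomers cannot be told apart in this read-out, and no preference between 3-methylphenyl and 2-methylphenyl can be drawn from them. No measurement of any kind is available that would explain this result or connect it to a property of either group.

The compounds shown leave open whether a single change on this aryl ring can step beyond the scatter at all, for example an amine or a carboxylic acid in place of the methyl. They also leave open whether the nitro group of compound 2, joined at another place on the ring, would behave as the methyl does when it is moved.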